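The source may hold more compounds than are shown below. What is called first, only, known or untested is meant among the compounds shown, and "the series" means these compounds.

Compound 1 `CCc1nc(-c2ccc(F)cc2)c(C(=O)N2CCN(c3cccc(Cl)c3)CC2)o1` and compound 2 `CCc1nc(-c2cccc(F)c2)c(C(=O)N2CCN(c3cccc(Cl)c3)CC2)o1` share one core, while compound 3 `COc1cc(OC)cc(N2CCN(C(=O)c3onc(C)c3-c3cccc(F)c3)CC2)c1` is built on a different core; how the two cores differ is not broken down here. In a functional assay on HL-60 cells (Homo sapiens) for inhibition, read by MTT assay, with a stated time of 72 h (a higher number here means a weaker inhibitor, a lower number a stronger inhibitor), compound 1 gives 169 nM, compound 2 gives 317 nM and compound 3 gives 152 nM. The change from compound 2 to compound 1 is 4-fluorophenyl in place of 3-fluorophenyl on an aromatic carbon, and it brought a 1.9-fold lower number from compound 2 to compound 1 (0.27 log units; within the scatter). Compound 4 `COc1cc(OC)cc(N2CCN(C(=O)c3onc(C)c3-c3ccc(F)cc3)CC2)c1` has not been measured; it arises from compound 3 by 4-fluorophenyl in place of 3-fluorophenyl on an aromatic carbon, the same kind of change, though the surroundings differ: in compound 4 the place is next to the ring atom that bears a methyl group and two ring bonds from the ring nitrogen, whereas in compound 1 it is next to the ring nitrogen and two ring bonds from the ring atom that bears an ethyl group. Compound 4 is expected to show a step of about a 1.5-fold lower number from compound 3 to compound 4 (0.18 log units; within the scatter) in this assay, close in size to the earlier one, because compound 3 stands at 152 nM and the same kind of change gave a 1.9-fold lower number from compound 2 to compound 1 (0.27 log units; within the scatter). Compound 4 is therefore estimated at 100 nM, between 50 nM and 220 nM.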

Compound 4, half-maximal inhibitory concentration: 475 nM
Compound 4: the middle estimate sits 4.8-fold (0.68 log units) below what was measured; the measured number lies above the stated range.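

In this assay the same swap gave a 3.1-fold higher number from compound 3 to compound 4 (0.49 log units; beyond the scatter), so a result seen on one core could not simply be carried over to the other. The two steps differ by more than repeated measurements would explain: the same change on two cores in this assay, a 1.9-fold lower number (0.27 log units; within the scatter) from compound 2 to compound 1 and a 3.1-fold higher number (0.49 log units; beyond the scatter) from compound 3 to compound 4, 5.9-fold (0.77 log units) apart, beyond the scatter of two such steps. This shows that, for these two pairs, the outcome of the change depends on the core, but it does not show which difference between the cores is responsible, and two pairs set no general rule for the series.

Still open, on these data alone, is how a plain phenyl group or a pyridine ring in place of the fluorophenyl would behave on either core. Also open, as far as these compounds go, is whether the step would hold on a third core.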